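Swapping hydroxy for fluoro in a quiet series

The compounds below may be only part of what the source reports. "The series", "measured", "known", "first", "only" and "open" are said of these compounds alone.

Values in a functional assay on HCT-8 cells (Homo sapiens) for cytotoxicity (on this read-out lower numbers stand for an effect already at smaller amounts and higher numbers for an effect only at larger amounts of compound), so far:
Compound 1 `CCOc1cc(-c2ccccc2)nc2ccccc12` gives > 10 ug/mL as a limit
Compound 2 `Oc1ccc2c(O)cc(-c3ccccc3)nc2c1` gives > 10 ug/mL as a limit
Compound 3 `CCCOc1cc(-c2ccccc2)nc2ccccc12` gives > 10 ug/mL as a limit

Compound 2 stands at > 10 ug/mL in this assay as a limit and not as a number. Compound 4 `Oc1cc(-c2ccccc2)nc2cc(F)ccc12` differs from it in one place (fluoro in place of hydroxy on an aromatic carbon): fluoro in place of hydroxy on an aromatic carbon. One measured step exists (a step that the two limits leave unreadable from compound 1 to compound 3) and it concerns a different change, methyl in place of hydrogen on a saturated chain carbon, so it offers no size to carry over. For the measured compounds named here, the series as a whole is described by the limit of > 10 ug/mL in this assay, at which 3 of the 3 values shown sit, and no compound in it has yet given a readable number. In this assay no step beyond the scatter is therefore expected, and no direction can be argued from the data. The expected step that the limit leaves unreadable from compound 2 to compound 4 is estimated to be small. For compound 4 the estimated value is 12 ug/mL with an expected range from 4 ug/mL to 30 ug/mL and a report as a limit again seems likely.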

Compound 4, half-maximal effective concentration: 3.45 ug/mL
The estimate for compound 4 lay 3.5-fold (0.54 log units) above the measured number; the whole stated range lies above it.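

In this assay, fluoro in place of hydroxy on this aromatic carbon gives an at least 2.8-fold lower number from compound 2 to compound 4 (0.46 log units; beyond the scatter). For the compounds shown here, this shows that the read-out can respond to a change at this place, meta to a fused ring and para to a fused ring, which the earlier compounds did not show, since the one change they offered, methyl in place of hydrogen on a saturated chain carbon, cannot be read between two limits. Compound 4 is also the only compound shown that gives a readable number: the limit of > 10 ug/mL in this assay, at which 3 of the 4 values shown sit.

The step has only a lower bound on its size, and the compounds shown do not separate the entry of fluoro from the departure of hydroxy. Going by these compounds, whether plain hydrogen, chloro, methoxy or an amine at this place would give a similar number remains open.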